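The compounds below may be only part of what the source reports. "The series", "measured", "known", "first", "only" and "open" are said of these compounds alone.

Measured so far:
compound 1 `O=C(Nc1ccc(Oc2ccnc3[nH]ccc23)cc1)c1cc2cccnc2n(-c2ccc(Br)cc2F)c1=O`: 2360 nM
compound 2 `O=C(Nc1ccc(Oc2ccnc3[nH]ccc23)c(F)c1)c1cc2cccnc2n(-c2ccc(Br)cc2F)c1=O`: 820 nM
compound 3 `Cn1ccc2c(Oc3ccc(NC(=O)c4cc5cccnc5n(-c5ccccc5)c4=O)cc3)ccnc21`: 620 nM

All three were tested in a functional assay on HT-29 cells (Homo sapiens) for antiproliferative activity, read by MTT assay, with a stated time of 72 h; a lower number here means a stronger inhibitor, a higher number a weaker inhibitor. In this assay compound 1 gives 2360 nM and compound 2 gives 820 nM; compound 3 gives 620 nM, which sits within the usual scatter of the number for compound 2, so no order between compound 2 and compound 3 can be read from these two values. Compound 2 differs from compound 1 by one change, (fluoro in place of hydrogen on an aromatic carbon), and this brought a 2.9-fold lower number from compound 1 to compound 2 (0.46 log units; beyond the scatter). The difference between the core of compound 1 and the core of compound 3 is not broken down here.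

Compound 4 `Cn1ccc2c(Oc3ccc(NC(=O)c4cc5cccnc5n(-c5ccc(F)cc5)c4=O)cc3)ccnc21` has not yet been measured. It differs from compound 3 by fluoro in place of hydrogen on an aromatic carbon. Within the data shown here, this is the same kind of change as the one from compound 1 to compound 2, but the place is not the same: in compound 2 the fluoro sits ortho to a large group and meta to a large group, whereas in compound 4 it sits para to a large group. Among the measured compounds shown here, only one earlier example of this kind of change exists, and it is at a different place, so the expected step for compound 4 is smaller and given a wide range: a 1.4-fold lower number from compound 3 to compound 4 (0.14 log units; within the scatter) in this assay, because the same kind of change gave a 2.9-fold lower number from compound 1 to compound 2 (0.46 log units; beyond the scatter). On this basis compound 4 is estimated at 450 nM, with a range from 200 nM to 1000 nM.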

Compound 4, half-maximal inhibitory concentration: 250 nM
Compound 4: middle estimate off by 1.8-fold (0.26 log units), on the high side; the range from low to high includes it.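

In this assay, going from phenyl to 4-fluorophenyl gave a 2.5-fold lower number from compound 3 to compound 4 (0.39 log units; beyond the scatter) and so lowered the number by a margin that can be read. Set beside the earlier fluoro step, this gives two steps of matching size: the same change on two cores in this assay, a 2.9-fold lower number (0.46 log units; beyond the scatter) from compound 1 to compound 2 and a 2.5-fold lower number (0.39 log units; beyond the scatter) from compound 3 to compound 4, 1.2-fold (0.06 log units) apart, within the scatter of two such steps. So, in these two pairs, adding one fluoro to an aromatic carbon lowered the number on both cores, and by a similar amount. This does not show that the change carries over at one fixed place, as the fluoro enters at a different place in each pair, and two pairs are too few to make a rule or to tell why the number falls.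

The compounds shown leave open whether a chloro or a methoxy group at the same place on the phenyl ring would also lower the number. They also leave open whether the two fluoro changes would add up if both stood on a single compound.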